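The source may report more compounds than this note shows. Statements on the series, on what has been measured and on what is new or still open speak of the compounds shown alone.

Going by the values given here, in a functional assay on LFCl2A cells (Rattus norvegicus) for cytotoxicity (on this read-out higher numbers stand for weaker inhibition and lower numbers for stronger inhibition), compound 2 `CCCC(=O)OC[C@H]1O[C@H](CC2=CCCCC2)C=CC1=O` gives 90 nM, the lowest of the two numbers measured; its only neighbour, compound 1 `O=C1C=C[C@@H](CC2=CCCCC2)O[C@@H]1CO`, gives 3000 nM. Compound 3 `CC(=O)OC[C@H]1O[C@H](CC2=CCCCC2)C=CC1=O` differs from compound 2 by hydrogen in place of ethyl on a saturated chain carbon bound to a carbonyl carbon. Among the compounds with values here, the one measured step that bears on this is a 33-fold lower number from compound 1 to compound 2 (1.52 log units; beyond the scatter), where the whole propylcarbonyl group entered. Compound 3 keeps part of that group, so the number is expected to move back toward compound 1 by a fraction of that step, a 2.2-fold higher number from compound 2 to compound 3 (0.35 log units; beyond the scatter). Compound 3 is therefore estimated at 200 nM in this assay, within a range from 60 nM to 700 nM.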

Compound 3, half-maximal inhibitory concentration: 150 nM
Estimate against measurement, compound 3: 1.3-fold (0.12 log units) above; the measured number falls inside the stated range.
By their numbers in this assay, from the lowest: compounds 2 and 3 (each within the scatter of the next); then compound 1.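

In this assay, the ethyl part of propylcarbonyl makes no difference beyond the scatter: the change to acetyl gives a 1.7-fold higher number from compound 2 to compound 3 (0.22 log units; within the scatter) and leaves compound 2 and compound 3 indistinguishable. Acetyl on the oxygen on a saturated carbon is enough for a large step, a 20-fold lower number from compound 1 to compound 3 (1.30 log units; beyond the scatter), so this step does not need the longer acyl chain. No available evidence bears on what lies behind these steps. Still open, on these data alone, is whether a longer chain or a benzoyl ester would keep this number, and whether the ester linkage itself matters, as a methyl ether or an amine at this place would show.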